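The source may report more compounds than this note shows. Statements on the series, on what has been measured and on what is new or still open speak of the compounds shown alone.

In a toxicity assay on MRC5 cells (Homo sapiens) for inhibition, read by MTT assay, with a stated time of 72 h (on this read-out higher numbers stand for weaker inhibition and lower numbers for stronger inhibition), compound 1 `O=S(=O)(O)Oc1ccc(CCO)cc1` gives 106000 nM while compound 2 `CCCC(=O)OCCc1ccc(O)c(O)c1` gives 71500 nM and compound 3 `CCCCCCCCCCCC(=O)OCCc1ccc(O)cc1` gives 67200 nM as its value. Compound 2 thus lies within the scatter of both other compounds, and the three numbers do not separate from one another.

Compound 4 `CCCCCCCC(=O)OCCc1ccc(O)c(O)c1` is related to compound 2 through butyl in place of hydrogen on a saturated chain carbon, three bonds along the chain from a carbonyl carbon and the change is butyl in place of hydrogen on a saturated chain carbon, three bonds along the chain from a carbonyl carbon. Within the data shown here, no two measured compounds differ in only one place, so the series offers no direct measure of such a change.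

The nearest guide is compound 3, which also carries a long saturated chain and gives 67200 nM in this assay without standing apart from compound 2. Only a small step towards a lower number is therefore expected, and it should stay within the scatter. The expected move is a 1.6-fold lower number from compound 2 to compound 4 (0.20 log units; within the scatter) and it remains an estimate. For compound 4 the estimated value is 45000 nM with an expected range from 18000 nM to 95000 nM across repeat measurements.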

Compound 4, half-maximal inhibitory concentration: 104000 nM
For compound 4 the middle estimate is 2.3-fold (0.36 log units) below the measured one, outside the stated range (above it).
By their numbers in this assay, from the lowest: compounds 3, 2, 4 and 1 (each within the scatter of the next).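

Among these compounds, the step at this position, butyl in place of hydrogen on a saturated chain carbon, three bonds along the chain from a carbonyl carbon, gives the first direct comparison in this assay (a 1.5-fold higher number from compound 2 to compound 4 (0.16 log units; within the scatter)), and it lies within the scatter, so compound 2 and compound 4 do not separate. Read cut one bond further out as methyl to pentyl or ethyl to hexyl, the same difference shows that, for this one pair, an ester chain extended by a butyl group on the shared core leaves the read-out within the usual variation of the assay. No supporting measurement is available to account for this result.

On these data alone, a longer chain such as dodecyl on the core of compound 2, or a carboxylic acid or an amine at the end of the chain, remains open, as does whether any such group would give a step beyond the scatter. Compound 1 and compound 3 differ from compound 4 in more than one place, so they add no further reading of this chain change.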